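This account rests on a few compounds, and the source may have more. Where it says the series, first, only, none or still open, it means among the compounds named here.

Of the compounds shown here, three have been measured in a functional assay on T47D cells (Homo sapiens) for inhibition, read by sulforhodamine B assay, with a stated time of 48 h; on this read-out higher numbers stand for weaker inhibition of growth and lower numbers for stronger inhibition of growth. Compound 1 `COc1cc(C)cc(-c2c(-c3ccnc(-c4ccc(N(C)C)cc4)c3)cnn2CC#N)c1` gives 56 nM there, compound 2 `COc1cc(C)cc(-c2nn(CC#N)cc2-c2ccnc(-c3ccc(N(C)C)cc3)c2)c1` gives 475 nM, and compound 3 `COc1cc(C)cc(-c2nn(CC#N)cc2-c2ccc(-c3cccc(C(C)=O)c3)nc2)c1` gives 2230 nM. On these numbers compound 2 stands second highest of the three, between compound 1 and compound 3, with both gaps beyond the usual scatter.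

Compound 4 `Cc1cc(O)cc(-c2nn(CC#N)cc2-c2ccnc(-c3ccc(N(C)C)cc3)c2)c1` is not yet measured. It differs from compound 2 by one change: hydrogen in place of methyl on an oxygen on an aromatic ring.

Going by the values given here, no measured pair shows this change, so there is no step to lean on. The change from compound 2 to compound 4 is expected to be small, a 1.3-fold higher number from compound 2 to compound 4 (0.10 log units; within the scatter), probably not beyond the scatter. For compound 4 the estimated value in this assay is 600 nM, with a range from 200 nM to 2000 nM.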

Compound 4, concentration for 50% growth inhibition: 2590 nM
Estimate against measurement, compound 4: 4.3-fold (0.64 log units) below, outside the stated range (above it).
By their numbers in this assay, from the lowest: compound 1; then compound 2; then compounds 3 and 4 (each within the scatter of the next).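

In this assay, hydrogen in place of methyl on this oxygen, turning methoxy into hydroxy, gives a 5.5-fold higher number from compound 2 to compound 4 (0.74 log units; beyond the scatter) and so weakens growth inhibition beyond the scatter. Going by these compounds alone, this is the first step measured at this position, and it shows that a change of a single carbon here is enough to shift the read-out. Nothing available here accounts for the shift. On these data alone, whether ethoxy or an amine at this place would restore inhibition stays open. So does whether the same change would act alike on compound 1.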